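A few compounds are considered here, and "the series" means these few. Any claim that something is new, unique, unknown or untested is made for them only; others in the source may bear on it.

Three compounds that share one core differ only in the aromatic group attached to the sulfonyl sulfur. Compound 1 `CN(c1ccc2[nH]c(-c3n[nH]c4ccccc34)cc2n1)S(=O)(=O)c1ccc(Cl)cc1` carries a 4-chlorophenyl there, and in a functional assay on SMMC-7721 cells (Homo sapiens) for antiproliferative activity, read by MTT assay, with a stated time of 72 h (on this read-out higher numbers stand for weaker inhibition and lower numbers for stronger inhibition), compound 1 gives 12700 nM. Compound 2 `COc1ccc(S(=O)(=O)N(C)c2ccc3[nH]c(-c4n[nH]c5ccccc45)cc3n2)cc1` carries a 4-methoxyphenyl, and in this assay compound 2 gives 13000 nM. Compound 3 `COc1ccc(S(=O)(=O)N(C)c2ccc3[nH]c(-c4n[nH]c5ccccc45)cc3n2)c(OC)c1` carries a 2,4-dimethoxyphenyl, and in this assay compound 3 gives 10800 nM. Compound 3 has the lowest of the three numbers, yet the gaps to both neighbours are small: a 1.2-fold lower number from compound 1 to compound 3 (0.07 log units; within the scatter) and a 1.2-fold lower number from compound 2 to compound 3 (0.08 log units; within the scatter), both within the scatter, as is a 1.0-fold higher number from compound 1 to compound 2 (0.01 log units; within the scatter). None of the three substituent exchanges on this aromatic group has moved the number.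

Compound 4 `CN(c1ccc2[nH]c(-c3n[nH]c4ccccc34)cc2n1)S(=O)(=O)c1ccc(OC(F)(F)F)cc1` is not yet measured. Its change from compound 3 is 4-(trifluoromethoxy)phenyl in place of 2,4-dimethoxyphenyl on a sulfonyl sulfur. All three measured steps bear on this change, since each of them also exchanged substituents on the same aromatic group, and each stayed within the scatter. The step expected for this assay is therefore small, in no particular direction, and not beyond the scatter: a 1.1-fold higher number from compound 3 to compound 4 (0.05 log units; within the scatter). The number for compound 4 is estimated at 12000 nM, with a range from 6000 nM to 25000 nM.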

Compound 4, half-maximal inhibitory concentration: 7160 nM
For compound 4 the middle estimate is 1.7-fold (0.22 log units) above the measured one, within the range that was stated.
By their numbers in this assay, from the lowest: compounds 4, 3, 1 and 2 (each within the scatter of the next).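

With 4-(trifluoromethoxy)phenyl on the sulfonyl sulfur, a fourth aromatic group now stands at this position, and in this assay every new step stays within the scatter (a 1.5-fold lower number from compound 3 to compound 4 (0.18 log units; within the scatter)) (a 1.8-fold lower number from compound 2 to compound 4 (0.26 log units; within the scatter)) (a 1.8-fold lower number from compound 1 to compound 4 (0.25 log units; within the scatter)). The earlier compounds shown here covered only chloro and methoxy substituents, so this result extends the flat picture to a group that carries fluorine, including the exchange of methyl for trifluoromethyl on the oxygen. Across these four compounds, then, changing the substituents on this phenyl ring has produced no step that can be told apart from the scatter, and nothing measured here offers an explanation for that.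

Going by these compounds, all four compounds keep a six-membered aromatic ring of carbon only on the sulfur, so it remains open whether a group of another kind there, such as a saturated cyclohexyl ring, a longer alkyl chain, or a phenyl ring bearing an amine or a carboxylic acid, would give a step beyond the scatter. On these data alone, the methyl on the sulfonamide nitrogen and the rest of the shared core are also the same throughout, so what an exchange at those places would do remains unknown.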